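This account rests on a few compounds, and the source may have more. Where it says the series, first, only, none or still open, it means among the compounds named here.

Measured compounds:
- compound 1 `Nc1ncnc2c1nc(NCc1ccc(-c3ccncc3)cc1)n2[C@@H]1O[C@H](CO)[C@@H](O)[C@H]1O`, in an assay on COS-7 cells for inhibition of sodium/nucleoside cotransporter 2 (Homo sapiens), read by scintillation counting (on this read-out lower numbers stand for stronger inhibition and higher numbers for weaker inhibition), compound 1 gives 2700 nM
- compound 2 `COc1cc(CNc2nc3c(N)ncnc3n2[C@@H]2O[C@H](CO)[C@@H](O)[C@H]2O)ccc1-c1ccccc1`, compound 2 gives 1300 nM
- compound 3 `CCOc1cc(-c2ccccc2)ccc1CNc1nc2c(N)ncnc2n1[C@@H]1O[C@H](CO)[C@@H](O)[C@H]1O`, compound 3 gives 5400 nM

Compound 2 has the lowest number of the three. Its nearest neighbour is compound 1, whose number is higher by a margin beyond the usual scatter; compound 3 lies further off, also beyond the scatter. For the measured compounds named here, no single-point step between measured compounds is available, so the values can only be read side by side: compound 2 with a methoxy group sits lower than compound 3 with an ethoxy group, and that gap is beyond the scatter.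

Compound 4 `COC(=O)COc1cc(CNc2nc3c(N)ncnc3n2[C@@H]2O[C@H](CO)[C@@H](O)[C@H]2O)ccc1-c1ccccc1` is not yet measured. It differs from compound 2 by methoxycarbonyl in place of hydrogen on a saturated chain carbon bound to an oxygen on an aromatic ring. Going by the values given here, no measured step of this kind exists. Given that compound 3 with its larger alkoxy group reads 5400 nM against 1300 nM for compound 2, the expectation is a small to moderate rise in the number for compound 4, a step of a 2.0-fold higher number from compound 2 to compound 4 (0.30 log units; within the scatter) that may or may not clear the scatter. The estimate for compound 4 in this assay is 2600 nM, within 900 nM to 7500 nM.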

Compound 4, half-maximal inhibitory concentration: 3300 nM
Compound 4: middle estimate off by 1.3-fold (0.10 log units), on the low side; the range from low to high includes it.
By their numbers in this assay, from the lowest: compound 2; then compounds 1, 4 and 3 (each within the scatter of the next).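

In this assay, for the compounds shown here, replacing hydrogen with methoxycarbonyl on the saturated chain carbon bound to an oxygen on an aromatic ring gives the first single-place step: a 2.5-fold higher number from compound 2 to compound 4 (0.40 log units; beyond the scatter). This place therefore tolerates the change from methoxy to (methoxycarbonyl)methoxy with a modest loss, and compound 4 still gives a measurable 3300 nM. Nothing available bears on why the number rises.

The compounds shown leave open whether the rise follows the carbonyl or the added chain length; a carboxylic acid, a primary amide or a plain propoxy chain at this place would help separate the two. On these data alone, it also remains open whether the same replacement would give a step of similar size on the core of compound 1 .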